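Swapping the imine substituent on a weak MCF7 inhibitor

The source may report more compounds than this note shows. Statements on the series, on what has been measured and on what is new or still open speak of the compounds shown alone.

Compound 1 `CCOC(=O)C1=C(N/C=N/c2nnc(S(N)(=O)=O)s2)Nc2[nH]nc(C)c2C1c1ccc(N(C)C)cc1` gives 34500 nM in a functional assay on MCF7 cells (Homo sapiens) for inhibition, read by MTT assay, with a stated time of 48 h; a higher number here means a weaker inhibitor, a lower number a stronger inhibitor.
Compound 2 `CCOC(=O)C1=C(N)Nc2[nH]nc(C)c2C1c1ccc(N(C)C)cc1` gives 5060 nM in this assay.
Compound 3 `CCOC(=O)C1=C(N/N=C(/C(=O)Br)c2ccc(Cl)cc2)Nc2[nH]nc(C)c2C1c1ccc(N(C)C)cc1` gives 46300 nM in this assay.

Compound 1 stands second highest of the three numbers; its nearest neighbour is compound 3, with a 1.3-fold higher number from compound 1 to compound 3 (0.13 log units; within the scatter), and its furthest is compound 2, with a 6.8-fold lower number from compound 1 to compound 2 (0.83 log units; beyond the scatter). Compound 4 `CCOC(=O)C1=C(N/C=N/c2ccc([N+](=O)[O-])cc2)Nc2[nH]nc(C)c2C1c1ccc(N(C)C)cc1` differs from compound 1 in one place: 4-nitrophenyl in place of 5-sulfamoyl-1,3,4-thiadiazol-2-yl on a double-bonded nitrogen. Among the compounds with values here, two measured steps bear on this. Removing the whole group from the amine nitrogen gave a 6.8-fold lower number from compound 1 to compound 2 (0.83 log units; beyond the scatter), and putting a different group in its place gave a 1.3-fold higher number from compound 1 to compound 3 (0.13 log units; within the scatter), with a 9.2-fold higher number from compound 2 to compound 3 (0.96 log units; beyond the scatter) pointing the same way. Compound 4 keeps a group of the same size on that nitrogen, so the exchange resembles the step to compound 3 rather than the step to compound 2. The expectation is therefore a change no larger than the scatter, with a 1.2-fold lower number from compound 1 to compound 4 (0.06 log units; within the scatter) as the estimated step. Compound 4 is expected to give 30000 nM in this assay, within a range from 12000 nM to 75000 nM.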

Compound 4, half-maximal inhibitory concentration: 58600 nM
For compound 4 the middle estimate is 2.0-fold (0.29 log units) below the measured one; the measured number falls inside the stated range.
By their numbers in this assay, from the lowest: compound 2; then compounds 1, 3 and 4 (each within the scatter of the next).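

In this assay the exchange of 5-sulfamoyl-1,3,4-thiadiazol-2-yl for 4-nitrophenyl on the double-bonded nitrogen gave a 1.7-fold higher number from compound 1 to compound 4 (0.23 log units; within the scatter) and so left the number unchanged within the scatter, even though the entering ring is of carbon only and has no hydrogen-bond donors. With a 1.3-fold higher number from compound 3 to compound 4 (0.10 log units; within the scatter) as well, the three large groups carried by compound 1, compound 3 and compound 4 all lie within the scatter of one another, and a 12-fold higher number from compound 2 to compound 4 (1.06 log units; beyond the scatter) sets the free amine of compound 2 apart from this latest group too. No measurement shown here accounts for this result.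

Going by these compounds, it remains open whether a small acetyl group on the amine nitrogen would give a number nearer that of compound 2 or that of the other three. On these data alone, it is also open whether an amine or a carboxylic acid in place of the nitro group of compound 4 would move the number at all.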